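From Ester to Carbonate on a Shared Core

The source may report more compounds than this note shows. Statements on the series, on what has been measured and on what is new or still open speak of the compounds shown alone.

Among the compounds with values here, compound 3 `Cc1cn(C2CC(N=[N+]=[N-])C(COC(=O)CCCC(=O)O)O2)c(=O)[nH]c1=O` is the one member of this small set for which an ADME assay on the whole organism (serum) with Homo sapiens as the target (a lower number here means that the compound disappears faster, a higher number that the compound lasts longer), returns an actual number: in this assay compound 3 gives 30 h. Compound 1 `Cc1cn(C2CC(N=[N+]=[N-])C(COC(=O)NCCCO)O2)c(=O)[nH]c1=O` reaches only a limit of the assay, > 48 h. Compound 2 `Cc1cn(C2CC(N=[N+]=[N-])C(COC(=O)NCCCC(=O)OC(C)(C)C)O2)c(=O)[nH]c1=O` likewise stops at a limit, > 48 h. the limit of > 48 h in this assay, at which 2 of the 3 values shown sit, leaves the step that the two limits leave unreadable from compound 1 to compound 2 unreadable, and the step of an at least 1.6-fold lower number from compound 1 to compound 3 (0.20 log units; that floor lies within the scatter) sets no more than a floor. Compound 4 `Cc1cn(C2CC(N=[N+]=[N-])C(COC(=O)OCCCC(=O)O)O2)c(=O)[nH]c1=O` differs from compound 3 by 3-carboxypropoxy in place of 3-carboxypropyl on a carbonyl carbon. Within the data shown here, no measured step alters the linker to the carbonyl in this way, so no direction is indicated, and compound 4 is expected to show a step of a 1.2-fold lower number from compound 3 to compound 4 (0.08 log units; within the scatter). Compound 4 is therefore estimated at 25 h, with a range from 8 h to 60 h.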

Compound 4, half-life: 13 h
Compound 4: middle estimate off by 1.9-fold (0.28 log units), on the high side; the range from low to high includes it.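

In this assay, within the data shown here, 3-carboxypropoxy in place of 3-carboxypropyl on a carbonyl carbon gives a 2.3-fold lower number from compound 3 to compound 4 (0.36 log units; beyond the scatter), the first step here that has a definite size and lies beyond the scatter. This shows that the half-life responds to a change at this position, even though the two groups differ only by the oxygen that enters. Measured against the (3-hydroxypropyl)amino group, the same 3-carboxypropoxy group gives an at least 3.6-fold lower number from compound 1 to compound 4 (0.56 log units; beyond the scatter), which is only a floor: the limit of > 48 h in this assay, at which 2 of the 4 values shown sit.

On these data alone, it remains open whether a longer chain on this oxygen, or an amine in place of the carboxylic acid at its end, would shift the half-life in the same direction.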